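Methyl in place of trifluoromethyl: a paired comparison

The source may report more compounds than this note shows. Statements on the series, on what has been measured and on what is new or still open speak of the compounds shown alone.

Measured so far:
- compound 1, `NC(=O)c1c(NC(=O)c2ccc(C(F)(F)F)cc2)sc2c1CCN(C(=S)Nc1ccccc1Cl)C2`: 16400 nM in a functional assay on MKN-74 cells (Homo sapiens) for antiproliferative activity, with a stated time of 24 h; on this read-out lower numbers stand for stronger inhibition and higher numbers for weaker inhibition
- compound 2, `Cc1ccc(C(=O)Nc2sc3c(c2C(N)=O)CCN(C(=S)Nc2ccccc2Cl)C3)cc1`: in this assay compound 2 gives 11300 nM
- compound 3, `NC(=O)c1c(NC(=O)c2ccccc2Br)sc2c1CCN(C(=S)Nc1ccccc1C(F)(F)F)C2`: in this assay compound 3 gives 24300 nM

Compound 4, `Cc1ccccc1NC(=S)N1CCc2c(sc(NC(=O)c3ccccc3Br)c2C(N)=O)C1`, is not yet measured. It is related to compound 3 by methyl in place of trifluoromethyl on an aromatic carbon. The same kind of change has already been made once among the measured compounds, from compound 1 to compound 2, where it reads methyl in place of trifluoromethyl on an aromatic carbon and made the step of a 1.5-fold lower number from compound 1 to compound 2 (0.16 log units; within the scatter). The two occurrences are the same kind of change, not the same: in the measured pair the group sits para to a large group, in the new pair ortho to a large group. The difference between the core of compound 1 and the core of compound 3 is not broken down here; their values in this assay lie within the scatter of each other, while compound 2 and compound 3 lie beyond it.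

Against that background, compound 4 is expected to follow compound 3 with a step of about a 1.5-fold lower number from compound 3 to compound 4 (0.18 log units; within the scatter), resting only on the size of a 1.5-fold lower number from compound 1 to compound 2 (0.16 log units; within the scatter). The estimate for compound 4 in this assay is therefore 16000 nM, with a likely range from 7000 nM to 36000 nM.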

Compound 4, half-maximal inhibitory concentration: > 50000 nM
Compound 4: only a limit was reported; the forecaster's own chance of this, stated with the estimate: 10%; at least 3.1-fold (0.49 log units) between middle value and limit.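

In this assay compound 4 gives > 50000 nM, which is a limit of the assay and not a number. Methyl in place of trifluoromethyl does not carry over between these cores as a fixed step, with an at least 2.0-fold higher number from compound 3 to compound 4 (0.31 log units; beyond the scatter) standing against the earlier pair: the same change on two cores in this assay, a 1.5-fold lower number (0.16 log units; within the scatter) from compound 1 to compound 2 and an at least 2.0-fold higher number (0.31 log units; beyond the scatter) from compound 3 to compound 4, at least 2.9-fold (0.47 log units) apart, beyond the scatter of two such steps. Two pairs cannot separate the effect of the core from that of the group's place, here ortho to a large group, and the true size of the new step remains unread with this value at the limit: the limit of > 50000 nM in this assay, at which 1 of the 4 values shown sits.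

Still open, as far as these compounds go, is how a methoxy group or an ethyl chain at the same place would read on the core of compound 3. Also open, from the compounds shown here alone, is whether methyl in place of trifluoromethyl, ortho to a large group, would give a step of the same direction on a second core.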